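Removing One Fluoro from Compound 1

The source may report more compounds than this note shows. Statements on the series, on what has been measured and on what is new or still open speak of the compounds shown alone.

Within the data shown here, compound 1, `COc1cc(-c2nnc3n2NC(c2ccco2)C(C(=O)c2ccc(F)c(F)c2)S3)cc(OC)c1OC`, is the only compound of this set with a full number in a functional assay on MCF7 cells (Homo sapiens) for cytotoxicity, read by MTT assay, with a stated time of 48 h; on this read-out lower numbers stand for stronger inhibition and higher numbers for weaker inhibition: compound 1 gives 73200 nM. Compound 2, `COc1cccc(C(=O)C2Sc3nnc(-c4cc(OC)c(OC)c(OC)c4)n3NC2c2ccco2)c1`, reaches only a limit of the assay in this assay, where compound 2 gives > 100000 nM. Among the measured compounds shown here, the step of an at least 1.3-fold higher number from compound 1 to compound 2 (0.13 log units; that floor lies within the scatter), in which 3-methoxyphenyl replaces 3,4-difluorophenyl on a carbonyl carbon, is the only measured step, and its floor rests on (the limit of > 100000 nM in this assay, at which 1 of the 2 values shown sits).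

Compound 3, `COc1cc(-c2nnc3n2NC(c2ccco2)C(C(=O)c2ccc(F)cc2)S3)cc(OC)c1OC`, differs from compound 1 by hydrogen in place of fluoro on an aromatic carbon. For the measured compounds named here, no measured step touches this position; the one measured step concerns a different replacement on the same carbonyl carbon, so it bears on compound 3 only by showing how close compound 1 already sits to the limit. In this assay no more than a small step is expected, in no sure direction, and the estimated step is a 1.2-fold higher number from compound 1 to compound 3 (0.09 log units; within the scatter). Compound 3 is therefore expected to give about 90000 nM, between 35000 nM and 200000 nM, with a fair chance that only a limit is reported.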

Compound 3, half-maximal inhibitory concentration: > 100000 nM
Compound 3 ended at the assay's limit (the forecaster's own chance of this, stated with the estimate: 45%); middle value at least 1.1-fold (0.04 log units) from the limit.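

In this assay, the change from 3,4-difluorophenyl to 4-fluorophenyl gives an at least 1.3-fold higher number from compound 1 to compound 3 (0.13 log units; that floor lies within the scatter). Among these compounds, this gives the position a measured step of its own, but it shows only that the number for compound 3 lies past a limit of the assay, not how far past, and the floor of the step does not go beyond the scatter. Compound 2 and compound 3 both stand at a limit, so the step between them cannot be read, and 3-methoxyphenyl and 4-fluorophenyl on the carbonyl carbon cannot be put in any order; the reading of this position therefore stays a floor, with compound 1 the only full number: the limit of > 100000 nM in this assay, at which 2 of the 3 values shown sit.

From the compounds shown here alone, it remains open whether the true size of the step from losing this fluoro is small or large, and whether the fluoro that stays in compound 3 has any bearing on the value. Also open, going by these compounds, is what a chloro group, an amine or a carboxylic acid would give in place of the fluoro on this aromatic carbon of the core of compound 1.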